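A few compounds are considered here, and "the series" means these few. Any claim that something is new, unique, unknown or untested is made for them only; others in the source may bear on it.

Measured so far:
- compound 1 `COc1cc(Cl)cc(-c2nn(-c3cccc(NC(=O)Nc4ccc(Cl)c(C(F)(F)F)c4)c3)cc2-c2ccncc2)c1`; in a functional assay on HCT-116 cells (Homo sapiens) for inhibition, read by sulforhodamine B assay, with a stated time of 48 h, tested at 1 uM (a higher number here means a weaker effect of the compound at the concentration tested, a lower number a stronger effect), compound 1 gives 38%
- compound 2 `COc1cc(Cl)cc(-c2nn(-c3cccc(NC(=O)Nc4cc(C(F)(F)F)cc(C(F)(F)F)c4)c3)cc2-c2ccncc2)c1`; in this assay compound 2 gives 7%
- compound 3 `COc1cc(Cl)cc(-c2nn(-c3cccc(NC(=O)Nc4ccc(Cl)c(Cl)c4)c3)cc2-c2ccncc2)c1`; in this assay compound 3 gives 71%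

Compound 3 stands highest of the three numbers in this assay, with compound 1 nearest and compound 2 furthest; both gaps lie beyond the scatter.

Compound 4 `COc1cc(Cl)cc(-c2nn(-c3cccc(NC(=O)Nc4cccc(C(F)(F)F)c4)c3)cc2-c2ccncc2)c1` differs from compound 3 as follows: 3-(trifluoromethyl)phenyl in place of 3,4-dichlorophenyl on an amide-type nitrogen.

Within the data shown here, one measured step bears on this: a number 33 percentage points higher from compound 1 to compound 3 (beyond the scatter). That step ran in the opposite sense to the present one, and compound 4 loses the second chloro as well, so a direct match is absent. Compound 2, carrying two trifluoromethyl groups, gives the lowest number of the three. Taken together, a step downward from compound 3 in this assay is expected, of a size comparable to the step between compound 1 and compound 3 but with wide uncertainty.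

The expected step is a number 26 percentage points lower from compound 3 to compound 4 (beyond the scatter). Compound 4 is therefore estimated at 45%, within a range of 25% to 70%.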

Compound 4, a percentage reported as activity, at one concentration (the size of the read-out at that concentration, not a potency): 43%
The estimate for compound 4 lay 2 percentage points above the measured number; the measured number falls inside the stated range.
By their numbers in this assay, from the lowest: compound 2; then compounds 1 and 4 (each within the scatter of the next); then compound 3.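

On the aryl group at the amide-type nitrogen, this assay gives a number 28 percentage points lower from compound 3 to compound 4 (beyond the scatter) when 3-(trifluoromethyl)phenyl replaces 3,4-dichlorophenyl, so one trifluoromethyl group alone suffices for this drop. Hydrogen in place of chloro gives a number 5 percentage points higher from compound 1 to compound 4 (within the scatter) and leaves that pair indistinguishable, whereas hydrogen in place of trifluoromethyl gives a number 36 percentage points higher from compound 2 to compound 4 (beyond the scatter) and marks a far larger step. The outcome of putting hydrogen on this ring therefore depends on which group leaves, at least across compound 1, compound 2 and compound 4.

Going by these compounds, whether a nitrile, an amine or a carboxylic acid on this ring would fit the same picture remains open, as does the result for an unsubstituted phenyl. No measurement shown explains these steps.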